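From compound 3 to compound 4: hydroxy to methoxy

The source may report more compounds than this note shows. Statements on the series, on what has been measured and on what is new or still open speak of the compounds shown alone.

Measured so far in a functional assay, read by spectrophotometry, with a stated time of 5 min; on this read-out lower numbers stand for stronger inhibition and higher numbers for weaker inhibition:
- compound 1 `COc1cc(/C=C/C(=O)C(=Cc2ccc(OC)c(OC)c2)C(=O)/C=C/c2ccc(O)c(OC)c2)ccc1O` gives 71000000 nM
- compound 2 `COc1cc(/C=C/C(=O)C(=Cc2ccc(O)cc2)C(=O)/C=C/c2ccc(O)c(OC)c2)ccc1O` gives 48700000 nM
- compound 3 `CCOc1cc(/C=C/C(=O)C(=Cc2ccc(O)c(OC)c2)C(=O)/C=C/c2ccc(O)c(OCC)c2)ccc1O` gives 60500000 nM

The value of compound 3 lies within the scatter of the values of both compound 1 and compound 2, so these three compounds cannot be ranked.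

Compound 4 `CCOc1cc(/C=C/C(=O)C(=Cc2ccc(OC)c(OC)c2)C(=O)/C=C/c2ccc(O)c(OCC)c2)ccc1O` has methyl in place of hydrogen on an oxygen on an aromatic ring, (methyl in place of hydrogen on an oxygen on an aromatic ring). This turns 4-hydroxy-3-methoxyphenyl into 3,4-dimethoxyphenyl.

Going by the values given here, one measured step bears on this group: 4-hydroxyphenyl in place of 3,4-dimethoxyphenyl on a double-bonded chain carbon gives a 1.5-fold lower number from compound 1 to compound 2 (0.16 log units; within the scatter). That step stays within the scatter, although it is a different exchange from the one at hand. Compound 1, which carries the 3,4-dimethoxyphenyl group, gives 71000000 nM, again within the scatter of compound 3.

No step beyond the scatter is therefore expected in this assay, and no direction is favoured. The expected step is a 1.1-fold higher number from compound 3 to compound 4 (0.03 log units; within the scatter). For compound 4 the estimated value is 65000000 nM, with an expected range of 40000000 nM to 100000000 nM.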

Compound 4, half-maximal inhibitory concentration: 53200000 nM
Compound 4: middle estimate off by 1.2-fold (0.09 log units), on the high side, and the stated range covers the measured number.
By their numbers in this assay, from the lowest: compounds 2, 4, 3 and 1 (each within the scatter of the next).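

In this assay, methyl in place of hydrogen on an oxygen on an aromatic ring, which turns 4-hydroxy-3-methoxyphenyl into 3,4-dimethoxyphenyl, gives a 1.1-fold lower number from compound 3 to compound 4 (0.06 log units; within the scatter). Going by these compounds alone, this is the first direct reading of this exchange at this position, as the earlier step replaced the whole aromatic group and did not isolate the hydroxy. In this pair, a free hydroxy at this place is not required to keep the number within the scatter, so capping it with methyl cannot be told apart from leaving it free. No available evidence bears on why this exchange behaves as it does.

From the compounds shown here alone, it remains open whether a larger group on this oxygen, such as a benzyl or a longer chain, or an amine in place of the hydroxy, would move the number beyond the scatter. Going by these compounds, it is also open whether the same methyl exchange on the other two hydroxy-bearing aromatic groups would stay within the scatter.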